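Extending the bromo-bearing chain towards compound 3

The source may hold more compounds than are shown below. What is called first, only, known or untested is meant among the compounds shown, and "the series" means these compounds.

- Compound 1 `C/C(=C\CC/C(C)=C/CC[C@@H]1[C@@]2(C)CCC(=O)C(C)(C)[C@@H]2CC[C@@]1(C)O)CC/C=C(\C)C(=O)OCCBr` gives > 30000 nM (a limit)
- Compound 2 `C/C(=C\CC/C(C)=C/CC[C@@H]1[C@@]2(C)CCC(=O)C(C)(C)[C@@H]2CC[C@@]1(C)O)CC/C=C(\C)C(=O)OCCCBr` gives 8100 nM

Among the compounds with values here, in a functional assay on HT-29 cells (Homo sapiens) for antiproliferative activity, read by sulforhodamine B assay, with a stated time of 96 h (on this read-out higher numbers stand for weaker inhibition and lower numbers for stronger inhibition), compound 2 gives 8100 nM as the only number so far. The value of compound 1 is a limit. Compound 3 `C/C(=C\CC/C(C)=C/CC[C@@H]1[C@@]2(C)CCC(=O)C(C)(C)[C@@H]2CC[C@@]1(C)O)CC/C=C(\C)C(=O)OCCCCBr` carries bromomethyl in place of bromo on a saturated chain carbon, three bonds along the chain from an oxygen next to a carbonyl group. Within the data shown here, the same exchange two bonds along the chain is the only step bearing on this, giving an at least 3.7-fold lower number from compound 1 to compound 2 (0.56 log units; beyond the scatter) and starting from a limit. In this assay a further modest lowering is therefore expected, an estimated 2.3-fold lower number from compound 2 to compound 3 (0.36 log units; beyond the scatter) on this one precedent. Compound 3 is estimated at 3500 nM (range 1000 nM to 12000 nM).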

Compound 3, half-maximal inhibitory concentration: 14600 nM
Estimate against measurement, compound 3: 4.2-fold (0.62 log units) below, outside the stated range (above it).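

In this assay the extra carbon does not repeat the earlier lowering: going from 3-bromopropyl to 4-bromobutyl gives a 1.8-fold higher number from compound 2 to compound 3 (0.26 log units; within the scatter), so the trend seen in the first step does not continue. The 2-bromoethyl exchange on the shorter chain still gives an at least 2.0-fold lower number from compound 1 to compound 3 (0.31 log units; beyond the scatter). Compound 1 stands as a limit: the limit of > 30000 nM in this assay, at which 1 of the 3 values shown sits.

The compounds shown leave open whether a longer chain, or a chloro group or an amine in place of the bromo, would move the number beyond the scatter.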